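Chlorinated Aryl Ureas Against the Dopamine Transporter

The source may hold more compounds than are shown below. What is called first, only, known or untested is meant among the compounds shown, and "the series" means these compounds.

Measured compounds:
Compound 1, `O=C(NCCCCC(c1ccc(F)cc1)c1ccc(F)cc1)Nc1ccc(I)cc1`: "not determined" (no result reported)
Compound 2, `CC(=O)Nc1cc(NC(=O)NCCCCC(c2ccc(F)cc2)c2ccc(F)cc2)ccc1Cl`: 609 nM
Compound 3, `O=C(NCCCCC(c1ccc(F)cc1)c1ccc(F)cc1)Nc1ccc(Cl)cc1C(F)(F)F`: "not determined" (no result reported)

For the measured compounds named here, compound 1 stands without a number in an ADME assay on isolated protein for inhibition of sodium-dependent dopamine transporter (Homo sapiens); on this read-out higher numbers stand for weaker inhibition and lower numbers for stronger inhibition; its result was not reported, and compound 3 shares that fate, so no step between measured compounds can be drawn. Only compound 2 supplies an anchor: in this assay compound 2 gives 609 nM. No pattern across the series can be claimed from a single number, and compounds 1 and 3 stand outside any comparison.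

The step from compound 1 to compound 4, `Cc1cc(Cl)ccc1NC(=O)NCCCCC(c1ccc(F)cc1)c1ccc(F)cc1`, consists of 4-chloro-2-methylphenyl in place of 4-iodophenyl on an amide-type nitrogen. Going by the values given here, since compound 1 has no value, the size and direction of this step cannot be read from the data; the shared core and the urea link are unchanged, and the only foothold is the value of compound 2, whose aryl group also carries a chlorine.

Compound 4 is therefore expected to land near the value of compound 2, with wide uncertainty: its estimated inhibition constant is 450 nM, within a range from 100 nM to 2000 nM.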

Compound 4, inhibition constant: 118 nM
The estimate for compound 4 lay 3.8-fold (0.58 log units) above the measured number; low and high end bracket the measured number.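

In this assay, the group on the amide-type nitrogen now has a first readable comparison: 4-chloro-2-methylphenyl in place of 3-acetamido-4-chlorophenyl gives a 5.2-fold lower number from compound 2 to compound 4 (0.71 log units; beyond the scatter), so the read-out at this position does respond to the aryl group, even with a chlorine present in both compounds. The steps that involve compound 1 or compound 3 cannot be read, so 4-iodophenyl stays outside the comparison and this result says nothing about that exchange. No measurement at hand accounts for the size or direction of the step.

From the compounds shown here alone, the two compounds with numbers differ in the whole aryl group, so it remains open whether the loss of the acetamido group, the entry of the methyl group or the different placing of the chlorine carries the step. Going by these compounds, it also remains open how the number would respond to a methoxy group, an amine or a carboxylic acid on this aryl group, or to a shorter or longer chain in the shared core.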